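A few compounds are considered here, and "the series" means these few. Any claim that something is new, unique, unknown or untested is made for them only; others in the source may bear on it.

Measured in an assay on membranes from CHO cells for displacement of a labelled ligand from adenosine receptor A1 (Homo sapiens), read by scintillation counting, with a stated time of 60 min, tested at 1 uM; a higher number here means more inhibition at the concentration tested (going by the name of the read-out), a lower number less inhibition:
compound 1 `CC(=O)C1=C(C)NC(=O)NC1c1ccsc1` gives 9%
compound 2 `CC1=C(C(=O)CC(C)C)C(c2ccsc2)NC(=O)N1` gives 37%
compound 3 `CC1=C(C(=O)OCC2CCC2)C(c2ccoc2)NC(=O)N1` gives 46%

Compound 3 carries the highest of the three numbers, though compound 2 lies within the scatter of it; only compound 1 lies beyond the scatter, lower. For the measured compounds named here, the single measured step, a number 28 percentage points higher from compound 1 to compound 2 (beyond the scatter), concerns the chain on the carbonyl and says nothing about the five-membered ring. Compound 4 `CC1=C(C(=O)OCC2CCC2)C(c2ccsc2)NC(=O)N1` differs from compound 3 by thiophen-3-yl in place of furan-3-yl on a saturated ring carbon. Going by the values given here, no measured pair isolates this exchange; compounds 1 and 2 carry thiophen-3-yl but differ from compound 3 elsewhere too. Among the compounds with values here, with no bearing step, no change beyond the scatter is expected in this assay, and the step of no change at the digits printed from compound 3 to compound 4 (within the scatter) is estimated as flat. Compound 4 is therefore expected to give about 46%, between 30% and 62%.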

Compound 4, a percentage reported as inhibition, at one concentration (the size of the read-out at that concentration, not a potency): 48%
Compound 4: middle estimate off by 2 percentage points, on the low side; low and high end bracket the measured number.
By their numbers in this assay, from the lowest: compound 1; then compounds 2, 3 and 4 (each within the scatter of the next, the first and the last beyond it).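

In this assay thiophen-3-yl in place of furan-3-yl on the saturated ring carbon gives a number 2 percentage points higher from compound 3 to compound 4 (within the scatter) and so shows no change at this position with cyclobutylmethoxy on the carbonyl carbon. With thiophen-3-yl held, the carbonyl substituent now reads directly: replacing isobutyl gives a number 11 percentage points higher from compound 2 to compound 4 (beyond the scatter) and replacing methyl gives a number 39 percentage points higher from compound 1 to compound 4 (beyond the scatter) as the steps for cyclobutylmethoxy. No measured evidence bears on these results.

Open, on these data alone, is whether the exchange stays flat with isobutyl or methyl on the carbonyl carbon. Phenyl or pyridin-3-yl at this position also remains open.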